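A longer chain on the aryl ether of compound 1

A few compounds are considered here, and "the series" means these few. Any claim that something is new, unique, unknown or untested is made for them only; others in the source may bear on it.

compound 1 `CCOc1ccc(C2CC2C(=O)NNC(=O)c2ccncc2)cc1`: 63000 nM
compound 2 `COc1ccc(C2CC2C(=O)NNc2nncc3ccccc23)cc1`: 83000 nM

In a functional assay on U-373MG ATCC cells (Homo sapiens) for inhibition, read by MTT assay, with a stated time of 72 h (a higher number here means a weaker inhibitor, a lower number a stronger inhibitor), compound 1 gives 63000 nM. Compound 2 gives 83000 nM, a gap within the scatter, so neither compound can be called the stronger. Compound 3 `CC(C)=CCC/C(C)=C/COc1ccc(C2CC2C(=O)NNC(=O)c2ccncc2)cc1` is compound 1 altered by 2,6-dimethylhepta-1,5-dien-1-yl in place of methyl on a saturated chain carbon bound to an oxygen on an aromatic ring, which turns the ethyl of the aryl ether into 3,7-dimethylocta-2,6-dien-1-yl. For the measured compounds named here, no measured pair shows such a step, so its direction rests on judgment alone. A modest gain is expected, a 2.1-fold lower number from compound 1 to compound 3 (0.32 log units; beyond the scatter), though a result within the scatter is nearly as plausible. Compound 3 is therefore estimated at 30000 nM, within 8000 nM to 100000 nM.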

Compound 3, half-maximal inhibitory concentration: 84000 nM
Estimate against measurement, compound 3: 2.8-fold (0.45 log units) below; the range from low to high includes it.
By their numbers in this assay, from the lowest: compounds 1, 2 and 3 (each within the scatter of the next).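

In this assay the change from ethyl to 3,7-dimethylocta-2,6-dien-1-yl on the aryl ether gives a 1.3-fold higher number from compound 1 to compound 3 (0.12 log units; within the scatter) and so counts as neither a gain nor a loss. This position therefore accepts a far larger chain, with two double bonds outside aromatic rings, without a readable shift in the number. Nothing measured here explains this result. From the compounds shown here alone, whether a shorter chain such as propyl, or an amine or a carboxylic acid at the end of the chain, would move the number beyond the scatter stays open.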